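Adding a nitro group to compound 1: a third placement

The source may report more compounds than this note shows. Statements on the series, on what has been measured and on what is new or still open speak of the compounds shown alone.

Measured so far in a functional assay on MCF7 cells (Homo sapiens) for cytotoxicity, read by MTT assay, with a stated time of 48 h (a lower number here means a stronger inhibitor, a higher number a weaker inhibitor), are these compounds:
Compound 1 `C/C(=N/NC(=S)Nc1ccccc1)c1ccccn1` gives 0.18 nM
Compound 2 `C/C(=N/NC(=S)Nc1cccc([N+](=O)[O-])c1)c1ccccn1` gives 38 nM
Compound 3 `C/C(=N/NC(=S)Nc1ccccc1[N+](=O)[O-])c1ccccn1` gives 5.7 nM

Compound 1 holds the lowest of these three numbers, and the other two compounds both lie well above it. Compound 4 `C/C(=N/NC(=S)Nc1ccc([N+](=O)[O-])cc1)c1ccccn1` has not yet been measured. It departs from compound 1 by one change, nitro in place of hydrogen on an aromatic carbon ( nitro in place of hydrogen on an aromatic carbon, para to a large group ).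

Among the compounds with values here, two measured steps bear directly on this change, since each is the same replacement made elsewhere on that ring. The expectation rests on a 210-fold higher number from compound 1 to compound 2 (2.32 log units; beyond the scatter) and on a 32-fold higher number from compound 1 to compound 3 (1.50 log units; beyond the scatter) as its two guides. Both steps are large, both lie beyond the scatter and both run towards a higher number. Within the data shown here, nothing measured so far shows how the place on the ring will act in compound 4, so a large step in the same direction is expected in this assay, probably of a size near those two. The estimate is therefore an 83-fold higher number from compound 1 to compound 4 (1.92 log units; beyond the scatter) as the expected step. Compound 4 is expected to give about 15 nM in a range from 2.5 nM to 90 nM as an estimate.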

Compound 4, half-maximal inhibitory concentration: 52 nM
Compound 4: the middle estimate sits 3.5-fold (0.54 log units) below what was measured; the measured number falls inside the stated range.
By their numbers in this assay, from the lowest: compound 1; then compound 3; then compounds 2 and 4 (each within the scatter of the next).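

In this assay, nitro para to a large group also gives a large rise, a 290-fold higher number from compound 1 to compound 4 (2.46 log units; beyond the scatter), so the replacement raises the number at all three places on this ring among the compounds shown, and none of them goes against this. The new place brings no return towards the parent value: compound 4 at 52 nM stands within the scatter of compound 2 at 38 nM, and of the three nitro compounds only compound 3 at 5.7 nM lies closer to compound 1. Nothing available accounts for the size of this step at this place.

As far as these compounds go, whether the rise belongs to nitro itself or would follow any replacement of hydrogen on this ring stays open, and an amine, a methoxy group or a chlorine atom para to a large group would speak to that. Also open is how the number would respond to changes elsewhere on the core of compound 1, as the compounds shown all differ on this one ring.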